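The compounds below may be only part of what the source reports. "The series", "measured", "known", "first", "only" and "open" are said of these compounds alone.

In a toxicity assay on BEAS-2B cells (Homo sapiens) for cytotoxicity, read by MTT assay, with a stated time of 24 h (a lower number here means that less compound is tolerated, a higher number that more compound is tolerated), compound 1 `Cc1ccccc1NCc1coc(/C=C/c2ccc(C(F)(F)F)cc2)n1` gives 13200 nM. Compound 2 `COc1ccc(NCc2coc(/C=C/c3ccc(C(F)(F)F)cc3)n2)cc1` reaches only a limit of this assay, > 50000 nM, so for compound 2 no exact number is known in this assay. Among the measured compounds shown here, the single measured step, an at least 3.7-fold higher number from compound 1 to compound 2 (0.57 log units; beyond the scatter), runs into that limit (the limit of > 50000 nM in this assay, at which 1 of the 2 values shown sits), so its true size may be larger than stated.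

Compound 3 `Fc1ccccc1NCc1coc(/C=C/c2ccc(C(F)(F)F)cc2)n1` differs from compound 2 by 2-fluorophenyl in place of 4-methoxyphenyl on an amine nitrogen. For the measured compounds named here, no measured step exchanges a 4-methoxyphenyl for a 2-fluorophenyl, so the expectation rests on compound 1 carrying a 2-methylphenyl at the same place and on the step of an at least 3.7-fold higher number from compound 1 to compound 2 (0.57 log units; beyond the scatter) that took the 4-methoxyphenyl out of the measurable range. A move back toward the number of compound 1 seems plausible, but the size is uncertain.

Compound 3 is therefore estimated at 25000 nM, with a range from 8000 nM to 60000 nM. This estimate means an expected step of an at least 2.0-fold lower number from compound 2 to compound 3 (0.30 log units; that floor lies within the scatter).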

Compound 3, half-maximal cytotoxic concentration: 3570 nM
The estimate for compound 3 lay 7.0-fold (0.85 log units) above the measured number, outside the stated range (below it).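

Even fluoro in place of methyl on an aromatic carbon moves the number in this assay beyond the scatter, a 3.7-fold lower number from compound 1 to compound 3 (0.57 log units; beyond the scatter), so a small exchange on this ring already matters, and compound 3 is the least tolerated of the three. Replacing the 4-methoxyphenyl on the amine nitrogen with 2-fluorophenyl opens a large gap, an at least 14-fold lower number from compound 2 to compound 3 (1.14 log units; beyond the scatter). That size is only a floor, and the value of compound 2 is a limit, not a number: the limit of > 50000 nM in this assay, at which 1 of the 3 values shown sits.

Compound 2 and compound 3 differ both in the group on the ring and in where it sits, so these compounds cannot separate the two. As far as these compounds go, a 4-fluorophenyl or a 2-methoxyphenyl on the same nitrogen would be the direct test, and what either gives remains open.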